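The source may report more compounds than this note shows. Statements on the series, on what has been measured and on what is new or still open speak of the compounds shown alone.

Measured in a functional assay on Ehrlich cells (Mus musculus) for cytotoxicity, read by MTT assay, with a stated time of 24 h; a higher number here means a weaker inhibitor, a lower number a stronger inhibitor:
- compound 1 `COc1cc(C)cc2c1C(=O)C=C(c1c(C)cc3c(c1OC)C(=O)C(Nc1ccc4ccccc4c1)=CC3=O)C2=O` gives 240 nM
- compound 2 `CCOC(=O)CNC1=CC(=O)c2cc(C)c(C3=CC(=O)c4c(OC)cc(C)cc4C3=O)c(OC)c2C1=O` gives 90 nM
- compound 3 `COc1cc(C)cc2c1C(=O)C=C(c1c(C)cc3c(c1OC)C(=O)C(N)=CC3=O)C2=O` gives 350 nM

Compound 3 belongs to the weak end of this small set. The scatter does not separate it from its nearest neighbour (a 1.5-fold higher number from compound 1 to compound 3 (0.16 log units; within the scatter)), while the gap to its furthest neighbour lies beyond the scatter (a 3.9-fold higher number from compound 2 to compound 3 (0.59 log units; beyond the scatter)).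

Compound 4 `COc1cc(C)cc2c1C(=O)C(N)=C(c1c(C)cc3c(c1OC)C(=O)C(N)=CC3=O)C2=O` differs from compound 3 by amino in place of hydrogen on a double-bonded ring carbon (amino in place of hydrogen on a double-bonded ring carbon, next to the ring atom that bears a large group). Within the data shown here, no measured step touches this carbon. All three measured steps change the substituent on an amine nitrogen, and they range from within the scatter to modest (a 2.7-fold lower number from compound 1 to compound 2 (0.43 log units; beyond the scatter)). They offer only a rough guide to the size of a step in this series and none to its direction.

No step beyond the scatter is therefore expected, and the estimated step is a 1.2-fold lower number from compound 3 to compound 4 (0.07 log units; within the scatter) with its direction uncertain. In this assay the estimated value for compound 4 is 300 nM (expected range 100 nM to 900 nM).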

Compound 4, half-maximal inhibitory concentration: 370 nM
Beside the measured number, compound 4's estimate is 1.2-fold (0.09 log units) below it; measured number inside the range.
By their numbers in this assay, from the lowest: compound 2; then compounds 1, 3 and 4 (each within the scatter of the next).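

In this assay, amino in place of hydrogen on the double-bonded ring carbon gives a 1.1-fold higher number from compound 3 to compound 4 (0.02 log units; within the scatter) and so opens no gap that can be told from the scatter. Among these compounds, this is the first reading at this carbon; the earlier steps all changed the substituent on an amine nitrogen, and one of them, a 3.9-fold higher number from compound 2 to compound 3 (0.59 log units; beyond the scatter), lies beyond the scatter. No measurement is at hand that bears on this result.

On these data alone, whether a chlorine or a hydroxyl on this ring carbon would also stay within the scatter of compound 3 remains open. So does whether a longer chain on the new amino nitrogen, such as a butyl chain, would produce a step beyond the scatter, as (ethoxycarbonyl)methyl does on the other amine nitrogen.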